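Chloro for Ethyl on a Urea Chain, Expected Effect

The source may hold more compounds than are shown below. What is called first, only, known or untested is meant among the compounds shown, and "the series" means these compounds.

Measured compounds:
compound 1, `CCCC(=O)Nc1ccc(S(=O)(=O)Oc2ccccc2C(C)C)cc1` — 4900 nM
compound 2, `CC(C)c1ccccc1OS(=O)(=O)c1ccc(NC(=O)CCl)cc1` — 5600 nM
compound 3, `CCCCCNC(=O)Nc1ccc(S(=O)(=O)Oc2ccccc2C(C)C)cc1` — 4900 nM

In a functional assay on HT-29 cells (Homo sapiens) for antiproliferative activity, read by sulforhodamine B assay, with a stated time of 48 h (on this read-out higher numbers stand for weaker inhibition and lower numbers for stronger inhibition), the three measured compounds sit close together. Compound 1 gives 4900 nM, compound 2 gives 5600 nM and compound 3 gives 4900 nM. The move from compound 1 to compound 2 is chloro in place of ethyl on a saturated chain carbon bound to a carbonyl carbon, and it produced a 1.1-fold higher number from compound 1 to compound 2 (0.06 log units; within the scatter). Compound 3 differs from compound 1 in its core, the difference being (pentylamino in place of propyl on a carbonyl carbon); that exchange gave no change at the digits printed from compound 1 to compound 3 (within the scatter), and the comparison of compound 2 with compound 3 shows a 1.1-fold lower number from compound 2 to compound 3 (0.06 log units; within the scatter).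

Compound 4, `CC(C)c1ccccc1OS(=O)(=O)c1ccc(NC(=O)NCCCCl)cc1`, has not yet been measured in this assay. Its difference from compound 3 is chloro in place of ethyl on a saturated chain carbon, three bonds along the chain from an amide-type nitrogen. Among the compounds with values here, this is the same kind of change as the one from compound 1 to compound 2, but not the same: there the chloro entered on a saturated chain carbon bound to a carbonyl carbon, whereas here it enters on a saturated chain carbon three bonds along the chain from an amide-type nitrogen.

With one earlier example of this kind of change, the step from compound 3 to compound 4 in this assay is expected to be a 1.1-fold higher number from compound 3 to compound 4 (0.04 log units; within the scatter), set beside a 1.1-fold higher number from compound 1 to compound 2 (0.06 log units; within the scatter), because compound 3 itself gives 4900 nM. Compound 4 is therefore estimated at 5400 nM, with a range from 2500 nM to 11000 nM.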

Compound 4, half-maximal inhibitory concentration: 6900 nM
Compound 4: middle estimate off by 1.3-fold (0.11 log units), on the low side, within the range that was stated.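

In this assay the new value gives three steps, a 1.4-fold higher number from compound 3 to compound 4 (0.15 log units; within the scatter), a 1.2-fold higher number from compound 2 to compound 4 (0.09 log units; within the scatter) and a 1.4-fold higher number from compound 1 to compound 4 (0.15 log units; within the scatter), and none of them stands clear of the usual scatter. Set beside the earlier example, chloro in place of ethyl reads alike on the two cores, as far as a single pair on each can tell: the same change on two cores in this assay, a 1.1-fold higher number (0.06 log units; within the scatter) from compound 1 to compound 2 and a 1.4-fold higher number (0.15 log units; within the scatter) from compound 3 to compound 4, 1.2-fold (0.09 log units) apart, within the scatter of two such steps This shows that the change carried from one core to the other without any difference that can be told from scatter, even though the chloro enters on a saturated chain carbon bound to a carbonyl carbon in one pair and on a saturated chain carbon three bonds along the chain from an amide-type nitrogen in the other, but it does not show that the change itself does anything in either core, and two small steps cannot establish a rule for the series.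

The compounds shown leave open whether an amine, a hydroxyl or a carboxylic acid at the end of the chain in place of the chloro, or a longer chain bearing the chloro, would give a number clearly apart from these. They also leave open whether the same step would hold on a core other than these two.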